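A few compounds are considered here, and "the series" means these few. Any claim that something is new, unique, unknown or untested is made for them only; others in the source may bear on it.

Going by the values given here, in a functional assay on MCF7 cells (Homo sapiens) for antiproliferative activity, read by sulforhodamine B assay, with a stated time of 48 h (a higher number here means a weaker inhibitor of growth, a lower number a stronger inhibitor of growth), compound 2 `NS(=O)(=O)NCCC1CCN(c2cc(-c3ccc(Cl)cc3)ncn2)CC1` gives 19700 nM, the lowest of the two numbers so far; compound 1 `Cc1ccc(-c2cc(N3CCC(CCNS(N)(=O)=O)CC3)ncn2)cc1` gives 47500 nM, and the step of a 2.4-fold lower number from compound 1 to compound 2 (0.38 log units; beyond the scatter) is the only one measured. Compound 3 `NS(=O)(=O)NCCC1CCN(c2cc(-c3ccccc3Cl)ncn2)CC1` differs from compound 2 by 2-chlorophenyl in place of 4-chlorophenyl on an aromatic carbon. Among the compounds with values here, no measured step moves the chlorine around its ring: the single known step exchanges methyl for chloro at a fixed position and does not bear on this change, so the direction is undetermined. No step beyond the scatter is expected, and the estimate for compound 3 is 20000 nM, between 7000 nM and 60000 nM, expected as a 1.0-fold higher number from compound 2 to compound 3 (0.01 log units; within the scatter).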

Compound 3, concentration for 50% growth inhibition: 44800 nM
Beside the measured number, compound 3's estimate is 2.2-fold (0.35 log units) below it, within the range that was stated.
By their numbers in this assay, from the lowest: compound 2; then compounds 3 and 1 (each within the scatter of the next).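

In this assay, going by these compounds alone, the chlorine's place on the phenyl ring affects the number: 2-chlorophenyl in place of 4-chlorophenyl gives a 2.3-fold higher number from compound 2 to compound 3 (0.36 log units; beyond the scatter) and is the first measured step with the atoms unchanged. Against the methyl compound, 2-chlorophenyl in place of 4-methylphenyl gives a 1.1-fold lower number from compound 1 to compound 3 (0.03 log units; within the scatter) and leaves the two compounds level. Of the three compounds, only the 4-chlorophenyl one stands apart, and no available evidence accounts for this.

The substituents shown on this ring are only chlorine and methyl. Going by these compounds, whether a methoxy group or an amine in place of the chlorine of compound 2 would hold, lower or raise the number remains open.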